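The source may hold more compounds than are shown below. What is called first, only, known or untested is meant among the compounds shown, and "the series" means these compounds.

Three related compounds have been tested in a functional assay on HL-60 cells (Homo sapiens) for cytotoxicity, read by MTT assay, with a stated time of 72 h; a lower number here means a stronger inhibitor, a higher number a weaker inhibitor. Compound 3 `COC(=O)c1sc2ccccc2c1Nc1cc(OC)c(OC)c(OC)c1` gives 1540 nM. Compound 1 `CCOC(=O)c1sc2ccccc2c1Nc1cc(OC)c(OC)c(OC)c1` differs from it by a single change, described as methyl in place of hydrogen on a saturated chain carbon bound to an oxygen next to a carbonyl group; in this assay compound 1 gives 5490 nM, so that change brought a 3.6-fold higher number from compound 3 to compound 1 (0.55 log units; beyond the scatter). Compound 2 `COC(=O)c1sc2ncccc2c1Nc1cc(OC)c(OC)c(OC)c1` carries a different core, and the difference between the two cores is not broken down here; in this assay compound 2 gives 2920 nM, a number that sits within the usual scatter of both compound 1 and compound 3, so no order among the three can be read from it.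

Compound 4 `CCOC(=O)c1sc2ncccc2c1Nc1cc(OC)c(OC)c(OC)c1` has not yet been measured. It stands to compound 2 exactly as compound 1 stands to compound 3: the change is methyl in place of hydrogen on a saturated chain carbon bound to an oxygen next to a carbonyl group, at the same place on a different core. Since this is the same change that produced a 3.6-fold higher number from compound 3 to compound 1 (0.55 log units; beyond the scatter), a step of about the same size is expected, and the expected step in this assay is a 3.3-fold higher number from compound 2 to compound 4 (0.51 log units; beyond the scatter). Because compound 2 gives 2920 nM, compound 4 is expected to give about 9500 nM, most likely between 4000 nM and 25000 nM.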

Compound 4, half-maximal inhibitory concentration: 6100 nM
Beside the measured number, compound 4's estimate is 1.6-fold (0.19 log units) above it; low and high end bracket the measured number.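

In this assay, putting ethoxycarbonyl in place of methoxycarbonyl on the core of compound 2 gives a 2.1-fold higher number from compound 2 to compound 4 (0.32 log units; beyond the scatter), and the earlier step on the other core points the same way, with the gap between the two steps no larger than repeated measurements could produce: the same change on two cores in this assay, a 3.6-fold higher number (0.55 log units; beyond the scatter) from compound 3 to compound 1 and a 2.1-fold higher number (0.32 log units; beyond the scatter) from compound 2 to compound 4, 1.7-fold (0.23 log units) apart, within the scatter of two such steps For these two cores, then, the step seen on one core carried over to the other in direction and, within the scatter, in size. This rests on just two pairs of compounds, so it sets no general rule for other cores, and it does not explain why the ethoxycarbonyl compounds give the higher numbers.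

The compounds shown hold only methoxycarbonyl and ethoxycarbonyl at this place, so it stays open whether a longer chain would move the number further in the same direction, and how a carboxylic acid or an amide there would compare. On these data alone, whether the step would hold on a third core also stays open.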